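Side-chain truncation on compound 2: hydroxymethyl variant

The source may hold more compounds than are shown below. What is called first, only, known or untested is meant among the compounds shown, and "the series" means these compounds.

Measured compounds in an assay on isolated protein for inhibition of ubiquitin carboxyl-terminal hydrolase 47 (Homo sapiens); on this read-out higher numbers stand for weaker inhibition and lower numbers for stronger inhibition:
Compound 1 `O=C([C@H]1Cc2cc(Cl)cc(-c3ccnc4[nH]ccc34)c2O1)N1CCNCC1` gives > 80000 nM.
Compound 2 `O=C([C@H]1Cc2cc(Cl)cc(-c3ccnc4cc(C(O)(CO)CCl)sc34)c2O1)N1CCNCC1` gives > 40000 nM.
Compound 3 `Cc1cc(Cl)cc(-c2ccnc3cc(CN4C(=O)C5C(C4=O)C5(C)C)sc23)c1O[C@@H]1CCNC[C@@H]1C` gives > 10000 nM.

Each of these three values is a limit of this assay and not a number. Compound 2 sits at the limit of > 40000 nM in this assay, at which 1 of the 3 values shown sits, so its inhibition is known only as weaker than that limit. The two other values shown are likewise limits, one at the limit of > 10000 nM in this assay, at which 1 of the 3 values shown sits, and one at the limit of > 80000 nM in this assay, at which 1 of the 3 values shown sits. Going by the values given here, no pair of measured compounds differs in a single place, so no step size within the set has been measured and no structural change has yet been tied to a movement of the read-out.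

Compound 4 `O=C([C@H]1Cc2cc(Cl)cc(-c3ccnc4cc(CO)sc34)c2O1)N1CCNCC1` is the next compound for this assay. It differs from compound 2 in one place: hydroxymethyl in place of 1-(chloromethyl)-1,2-dihydroxyethyl on an aromatic carbon. The change shortens the side chain on the five-membered ring while keeping the rest of the structure of compound 2 unchanged.

Among the compounds with values here, since every value shown so far is a limit, no measured step supports any expectation of a gain for compound 4; the expected step from compound 2 to compound 4 is a step that the limit leaves unreadable from compound 2 to compound 4, which is taken as none beyond the scatter. Compound 4 is therefore estimated at 50000 nM, with a range from 10000 nM to 200000 nM, and most likely reported again as a limit.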

Compound 4, half-maximal inhibitory concentration: > 40000 nM
Compound 4: no number, only a limit; the forecaster's own chance of this, stated with the estimate: 80%; the middle value does not contradict the limit.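

In this assay compound 4 gives > 40000 nM, a limit of the assay and not a number. Compound 2 also stands only as a limit, so no step can be read between compound 2 and compound 4. The compounds shown leave open how the side chain on the five-membered ring bears on inhibition.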